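Allyloxy in place of chloro: notes on compound 3

This account rests on a few compounds, and the source may have more. Where it says the series, first, only, none or still open, it means among the compounds named here.

Going by the values given here, compound 1 `Cc1cc(Nc2cc(Cl)cc(Br)c2)nc(N)n1` is one of two compounds measured so far in an assay on cells for inhibition of S-adenosylmethionine decarboxylase proenzyme (Homo sapiens), read by mass spectrometry, at pH 7.2, tested at 180 uM (a lower number here means less inhibition, a higher number more inhibition at the concentration tested (going by the name of the read-out)), and there compound 1 gives 33%. This is the higher of the two numbers, though the gap to its nearest neighbour is within the scatter. Compound 2 `Cc1cc(Nc2cc(Cl)cc(C#N)c2)nc(N)n1` gives 29% in this assay, and the step of a number 4 percentage points lower from compound 1 to compound 2 (within the scatter), cyano in place of bromo on an aromatic carbon, is within the scatter. Compound 3 `C=CCOc1cc(Br)cc(Nc2cc(C)nc(N)n2)c1` has not yet been measured in this assay. It differs from compound 1 by allyloxy in place of chloro on an aromatic carbon. Among the compounds with values here, no measured step replaces the chloro group; the only measured step, a number 4 percentage points lower from compound 1 to compound 2 (within the scatter), replaces the bromo group and is within the scatter, so it gives no direct guide to the size of the change to allyloxy. With nothing more to rest on, the step of a number 3 percentage points lower from compound 1 to compound 3 (within the scatter) is expected to stay within the scatter. The inhibition of compound 3 is therefore estimated at 30%, in a range from 10% to 55%.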

Compound 3, a percentage reported as inhibition, at one concentration (the size of the read-out at that concentration, not a potency): 28%
Estimate against measurement, compound 3: 2 percentage points above; measured number inside the range.
By their numbers in this assay, from the lowest: compounds 3, 2 and 1 (each within the scatter of the next).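

In this assay, going by these compounds alone, the only measured change at this position, allyloxy in place of chloro on an aromatic carbon, gives a number 5 percentage points lower from compound 1 to compound 3 (within the scatter) and so leaves the read-out within the scatter. The position, meta to a bromo group, thus accepts a group of 4 heavy atoms with 1 double bond outside aromatic rings and 1 hydrogen-bond acceptor in place of a single chlorine atom, with no measurable consequence in this read-out at one concentration; the other measured change, at the bromo group, gives a number 4 percentage points lower from compound 1 to compound 2 (within the scatter) and likewise stays within the scatter, so neither place varied in compound 1 has yet moved the number beyond it. No measurement at hand bears on why the read-out holds across this change.

Still open, going by these compounds, is whether an amine, a carboxylic acid or a longer alkoxy chain at this position would move the number beyond the scatter. Also open, on these data alone, is how the numbers in this assay relate to potency, since each comes from a single concentration, and what the allyloxy and cyano groups would give together on one compound.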